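The compounds below may be only part of what the source reports. "The series", "measured", "known", "first", "only" and "open" are said of these compounds alone.

The measured compounds:
compound 1, `CCCCCCNS(=O)(=O)NC(=O)Nc1c(C(C)C)cccc1C(C)C`: 8100 nM
compound 2, `CC(C)c1cc([N+](=O)[O-])cc(C(C)C)c1OC(=O)NS(=O)(=O)Oc1c(C(C)C)cccc1C(C)C`: > 50000 nM

In an assay on liver for inhibition of sterol O-acyltransferase 1 (Rattus norvegicus), using microsomes (on this read-out lower numbers stand for stronger inhibition and higher numbers for weaker inhibition), compound 1 gives 8100 nM. For compound 2 this assay reports only a limit, > 50000 nM. That entry is the limit of > 50000 nM in this assay, at which 1 of the 2 values shown sits, so no number is known for compound 2, and the gap between compound 1 and compound 2 cannot be counted as a step. Compound 3, `CC(=O)c1cc(C(C)C)c(OC(=O)NS(=O)(=O)Oc2c(C(C)C)cccc2C(C)C)c(C(C)C)c1`, is still to be measured. It differs from compound 2 in one place: acetyl in place of nitro on an aromatic carbon. Within the data shown here, no pair of measured compounds differs in one place, so no measured step shows how a change of this kind moves the read-out, and the starting point itself is a limit rather than a number. The expectation for compound 3 therefore rests on compound 2 alone, and no shift beyond the scatter is assumed in either direction. The expected step is a number no higher from compound 2 to compound 3 (the limit leaves the size open). Compound 3 is estimated at 50000 nM, with a range from 15000 nM to 150000 nM, and a second limit rather than a number is thought quite possible.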

Compound 3, half-maximal inhibitory concentration: 41800 nM
Estimate against measurement, compound 3: 1.2-fold (0.08 log units) above; low and high end bracket the measured number.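

In this assay, acetyl in place of nitro on an aromatic carbon, meta to two isopropyl groups and para to a large group, gives an at least 1.1-fold lower number from compound 2 to compound 3 (0.07 log units; that floor lies within the scatter). With acetyl on this carbon, compound 3 gives the position its first actual number, 41800 nM, so this position can now be read on a scale. The real size of the change remains unknown, and the printed floor does not establish any shift beyond the scatter, as compound 2 has only a limit and no number: the limit of > 50000 nM in this assay, at which 1 of the 3 values shown sits.

The compounds shown leave open how an amine, a carboxylic acid, a longer acyl chain or a plain hydrogen on this same aromatic carbon would read in this assay, and thus whether any group here can move the number clearly away from that of compound 3. They also leave open whether acetyl would give a similar reading if one of the two isopropyl groups on that ring were replaced by a methyl group.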